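A Chlorine Added Where Every Neighbour Sits at the Limit

The source may report more compounds than this note shows. Statements on the series, on what has been measured and on what is new or still open speak of the compounds shown alone.

Of the compounds shown here, three built on one shared core have been tested in an ADME assay on BaF3 cells (Mus musculus) for antiproliferative activity; on this read-out higher numbers stand for weaker inhibition of growth and lower numbers for stronger inhibition of growth. Compound 1 `Cc1ccc(NC(=O)c2cccc(C(F)(F)F)c2)cc1OC1CCN(C(=O)c2cccnc2)CC1` carries a pyridin-3-yl group on its carbonyl carbon. In this assay compound 1 gives > 10000 nM, which is a limit of the assay and not a number. Compound 2 `Cc1ccc(NC(=O)c2cccc(C(F)(F)F)c2)cc1OC1CCN(C(=O)c2ccno2)CC1` has a 1,2-oxazol-5-yl group in place of that pyridin-3-yl. In this assay compound 2 gives > 10000 nM, again a limit rather than a number. Compound 3 `CCC(=O)N1CCC(Oc2cc(NC(=O)c3cccc(C(F)(F)F)c3)ccc2C)CC1` has an ethyl group on the same carbonyl carbon. In this assay compound 3 gives > 10000 nM, also a limit.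

Compound 2 therefore stands where everything so far stands: the limit of > 10000 nM in this assay, at which 3 of the 3 values shown sit. The recorded steps, a step that the two limits leave unreadable from compound 1 to compound 2, a step that the two limits leave unreadable from compound 1 to compound 3 and a step that the two limits leave unreadable from compound 2 to compound 3, cannot be read in size, since two limits give no distance between them.

Compound 4 `Cc1ccc(NC(=O)c2cc(Cl)cc(C(F)(F)F)c2)cc1OC1CCN(C(=O)c2ccno2)CC1` is the compound still to be measured. Its difference from compound 2 is chloro in place of hydrogen on an aromatic carbon. Within the data shown here, none of the measured steps touches this ring; all three alter only the group on the carbonyl carbon, and none can be sized. There is thus no measured basis for any step beyond the scatter, and the expected step is a step that the limit leaves unreadable from compound 2 to compound 4. Compound 4 is estimated to give 15000 nM in this assay, within an expected range from 3000 nM to 60000 nM.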

Compound 4, concentration for 50% growth inhibition: > 10000 nM
Compound 4 ended at the assay's limit; the forecaster's own chance of this, stated with the estimate: 85%; the middle value does not contradict the limit.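

In this assay compound 4 gives > 10000 nM, which is a limit of the assay and not a number. Compound 2 also sits at a limit, so no size can be read for the step between compound 2 and compound 4. The compounds shown leave open how these four rank against one another and what would bring a value within reach of the assay, as all share one position: the limit of > 10000 nM in this assay, at which 4 of the 4 values shown sit.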